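From nitrophenyl to chlorophenyl on a shared core

This account rests on a few compounds, and the source may have more. Where it says the series, first, only, none or still open, it means among the compounds named here.

Compound 1 `N#CC1=C(N)N(c2ccc(S(N)(=O)=O)cc2)C2=C(CCCC2)C1c1ccccc1` carries a phenyl group on the shared core. In a functional assay on Ehrlich cells (Mus musculus) for cytotoxicity, read by trypan blue exclusion, with a stated time of 2 h (on this read-out higher numbers stand for weaker inhibition and lower numbers for stronger inhibition), compound 1 gives only a limit, > 100 ug/mL. Compound 2 `N#CC1=C(N)N(c2ccc(S(N)(=O)=O)cc2)C2=C(CCCC2)C1c1ccc([N+](=O)[O-])cc1` bears a 4-nitrophenyl group instead. In this assay compound 2 likewise gives only a limit, > 100 ug/mL. The step that the two limits leave unreadable from compound 1 to compound 2 therefore cannot be read, because both values sit at the limit of > 100 ug/mL in this assay, at which 2 of the 2 values shown sit. Compound 3 `N#CC1=C(N)N(c2ccc(S(N)(=O)=O)cc2)C2=C(CCCC2)C1c1ccccc1Cl` differs from compound 2 by 2-chlorophenyl in place of 4-nitrophenyl on a saturated ring carbon. Going by the values given here, no measured step bears on this change, and the values of compound 1 and compound 2 give no direction. Compound 3 is expected to give 150 ug/mL (range 80 ug/mL to 400 ug/mL), most likely again a limit. The step that the limit leaves unreadable from compound 2 to compound 3 is thus expected to stay within the scatter.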

Compound 3, half-maximal inhibitory concentration: > 100 ug/mL
Compound 3 was reported as a limit; the forecaster's own chance of this, stated with the estimate: 85%; the middle value does not contradict the limit.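

No new step can be read for compound 3 against compound 1 or compound 2, because all three values sit at one limit: (the limit of > 100 ug/mL in this assay, at which 3 of the 3 values shown sit). From the compounds shown here alone, whether any other group in this place on the shared core would give a readable value in this assay stays open.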